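Solubility notes: compound 2 to compound 3

The source may hold more compounds than are shown below. What is called first, only, known or untested is meant among the compounds shown, and "the series" means these compounds.

Compound 1 `Cc1noc(-c2nc(C)c3c(c2N)C(=O)N(Cc2ccc(Oc4ccc(F)cc4)cc2)C3=O)n1` gives 23800 nM in a physicochemical assay for solubility, using the shake flask method, in simulated intestinal fluid, measured as kinetic solubility, with a stated time of 2 h, at 25 degrees C, at pH 6.5; a higher number here means a more soluble compound, a lower number a less soluble compound. Compound 2 `Cc1noc(-c2nc(C)c3c(c2N)C(=O)N(Cc2cccc(F)c2)C3=O)n1` stands at a limit of this assay, < 5000 nM, so for it only a limit and no number is known (the limit of < 5000 nM in this assay, at which 1 of the 2 values shown sits). Compound 3 `Cc1noc(-c2nc(C)c3c(c2N)C(=O)N(Cc2ccc(Cl)cn2)C3=O)n1` is not yet measured and differs from compound 2 in one place: 5-chloropyridin-2-yl in place of 3-fluorophenyl on a saturated chain carbon bound to an amide-type nitrogen in a ring. Among the measured compounds shown here, no measured pair covers this change, so the size of the step rests on expectation alone. A rise in solubility somewhat beyond the usual scatter is expected, an at least 1.6-fold higher number from compound 2 to compound 3 (0.20 log units; that floor lies within the scatter). For compound 3 the estimated value in this assay is 8000 nM, in the range 2500 nM to 25000 nM.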

Compound 3, solubility: < 5000 nM
Compound 3: no number, only a limit (the forecaster's own chance of this, stated with the estimate: 35%); middle value at least 1.6-fold (0.20 log units) away from the limit.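

Compound 2 and compound 3 both stand at a limit and not at a number, so no step can be read between them: the limit of < 5000 nM in this assay, at which 2 of the 3 values shown sit.

The compounds shown leave open whether 5-chloropyridin-2-yl in place of 3-fluorophenyl changes solubility at all, and by how much.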